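The source may report more compounds than this note shows. Statements on the series, on what has been measured and on what is new or still open speak of the compounds shown alone.

Three compounds on the shared core have numbers in a functional assay on PC-3 cells (Homo sapiens) for antiproliferative activity, read by MTT assay, with a stated time of 24 h; a lower number here means a stronger inhibitor, a higher number a weaker inhibitor: compound 1 `CCN(CC)CCNC(=O)c1ccc(C(CC)(CC)c2ccc(OCS(=O)(=O)c3ccccc3)c(C)c2)n1CC` gives 7130 nM, compound 2 `CCN(CC)CCNC(=O)c1ccc(C(CC)(CC)c2ccc(OCSC)c(C)c2)n1CC` gives 4010 nM, and compound 3 `CCN(CC)CCNC(=O)c1ccc(C(CC)(CC)c2ccc(OCSc3ccccc3)c(C)c2)n1CC` gives 2230 nM. Compound 3 stands at the low end of these numbers, though it does not separate from one neighbour: a 1.8-fold lower number from compound 2 to compound 3 (0.25 log units; within the scatter). The only gap beyond the scatter that it shows is a 3.2-fold lower number from compound 1 to compound 3 (0.50 log units; beyond the scatter). The remaining pair also stays inside the scatter: a 1.8-fold lower number from compound 1 to compound 2 (0.25 log units; within the scatter).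

Next in the series is compound 4 `CCN(CC)CCNC(=O)c1ccc(C(CC)(CC)c2ccc(OCS(C)(=O)=O)c(C)c2)n1CC`, reached by methylsulfonyl in place of phenylsulfanyl on a saturated chain carbon bound to an oxygen on an aromatic ring. In words, this is methylsulfonyl in place of phenylsulfanyl on a saturated chain carbon bound to an oxygen on an aromatic ring. The change combines two measured moves, both run in reverse: sulfanyl back to sulfonyl, as in a 3.2-fold lower number from compound 1 to compound 3 (0.50 log units; beyond the scatter), and phenyl back to methyl on a sulfur, as in a 1.8-fold lower number from compound 2 to compound 3 (0.25 log units; within the scatter). As far as these compounds go, both reversed moves point towards a higher number, and whether they add up is untested in this small set. A rise beyond the scatter is therefore expected in this assay, with some allowance for incomplete addition. The estimated step is a 4.5-fold higher number from compound 3 to compound 4 (0.65 log units; beyond the scatter). For compound 4 the expected value is 10000 nM, with an estimated range of 4500 nM to 22000 nM.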

Compound 4, half-maximal inhibitory concentration: 46700 nM
The estimate for compound 4 lay 4.7-fold (0.67 log units) below the measured number; the whole stated range lies below it.
By their numbers in this assay, from the lowest: compounds 3, 2 and 1 (each within the scatter of the next, the first and the last beyond it); then compound 4.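

In this assay, sulfonyl in place of sulfanyl on the saturated chain carbon is now seen with both sulfur partners, and the cost is not constant: with methyl on the sulfur the change gives a 12-fold higher number from compound 2 to compound 4 (1.07 log units; beyond the scatter), while the phenyl pair reads a 3.2-fold lower number from compound 1 to compound 3 (0.50 log units; beyond the scatter). For the compounds shown here, the combined replacement is therefore much larger than the two earlier moves suggested, at a 21-fold higher number from compound 3 to compound 4 (1.32 log units; beyond the scatter), and methylsulfonyl is the one group of the four that separates from all the others. Phenyl and methyl on the sulfur are also no longer equivalent once the sulfur is a sulfonyl, as a 6.5-fold higher number from compound 1 to compound 4 (0.82 log units; beyond the scatter) shows, so the effect of that swap depends on which sulfur group carries it: the same change on two cores in this assay, a 1.8-fold lower number (0.25 log units; within the scatter) from compound 2 to compound 3 and a 6.5-fold lower number (0.82 log units; beyond the scatter) from compound 4 to compound 1, 3.6-fold (0.56 log units) apart, beyond the scatter of two such steps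

As far as these compounds go, whether a sulfinyl group, or an ethyl or benzyl on the sulfur, would fall with the sulfanyl compounds or with compound 4 stays open. This dependence rests on a single pair of steps on one core in one cell line, so how far it extends beyond these four compounds cannot be told.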